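Losing the Sulfur from the Hydroxybutyl Chain

A few compounds are considered here, and "the series" means these few. Any claim that something is new, unique, unknown or untested is made for them only; others in the source may bear on it.

Going by the values given here, in a functional assay on Raji cells (Homo sapiens) for inhibition, read by MTT assay, with a stated time of 96 h (a higher number here means that more compound is needed for the effect, a lower number that less compound is needed), compound 3 `CC(C)Cn1c(=O)n(C)c(=O)c2nc(SCCCCO)c(Cc3cccc4ccccc34)nc21` gives 37 nM, the lowest of the three numbers measured so far. Compound 1 `CC(C)Cn1c(=O)n(C)c(=O)c2c1nc(Cc1cccc3ccccc13)c(=O)n2CCCCO` gives 150 nM and compound 2 `CC(C)Cn1c(=O)n(C)c(=O)c2c1nc(Cc1cccc3ccccc13)c(=O)n2CCCCCO` gives 1420 nM. The next structure, compound 4 `CC(C)Cn1c(=O)n(C)c(=O)c2nc(CCCCO)c(Cc3cccc4ccccc34)nc21`, differs from compound 3 at one place: 4-hydroxybutyl in place of (4-hydroxybutyl)sulfanyl on an aromatic carbon. In words, 4-hydroxybutyl stands in place of (4-hydroxybutyl)sulfanyl on an aromatic carbon, ortho to a (naphthalen-1-yl)methyl group.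

Among the compounds with values here, no measured pair tests this exchange directly. The closest evidence is a 9.5-fold higher number from compound 1 to compound 2 (0.98 log units; beyond the scatter), where hydroxymethyl replaces hydroxy on a saturated chain carbon, four bonds along the chain from an aromatic nitrogen. That step shows that a small chain change can move the number well beyond the scatter, but it sits on a different kind of attachment. A modest rise in this assay is therefore expected, smaller than the step seen with compound 2 at 1420 nM. The expected change is a 3.2-fold higher number from compound 3 to compound 4 (0.51 log units; beyond the scatter). Compound 4 is estimated at 120 nM, with an expected range from 30 nM to 500 nM.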

Compound 4, half-maximal effective concentration: 285 nM
Compound 4: middle estimate off by 2.4-fold (0.38 log units), on the low side; measured number inside the range.
By their numbers in this assay, from the lowest: compound 3; then compounds 1 and 4 (each within the scatter of the next); then compound 2.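

In this assay, the exchange at this aromatic carbon gives a 7.7-fold higher number from compound 3 to compound 4 (0.89 log units; beyond the scatter), so removing the sulfur while keeping the four-carbon chain and its hydroxy group moves the number beyond the scatter. The earlier compounds shown here showed only a change in chain length on a ring nitrogen; this step shows that the link between the chain and the aromatic carbon also matters, even with the chain itself unchanged. Nothing measured on either group explains the rise. The compounds shown leave open whether an amine or an ether oxygen in place of the sulfur would keep the number close to that of compound 3 at 37 nM. They also leave open whether a longer chain on the sulfur would raise the number as it did on the ring nitrogen.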